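The source may report more compounds than this note shows. Statements on the series, on what has been measured and on what is new or still open speak of the compounds shown alone.

Measured compounds:
- Compound 1 `O=C(O)CCc1nnc(C(=O)Nc2cccc(-c3ccc(F)cc3)c2)s1`, which in a functional assay on CHO cells for agonist activity at Free fatty acid receptor 1 (Homo sapiens), read by calcium flux (a higher number here means that more compound is needed for the effect, a lower number that less compound is needed), gives 1280 nM.
- Compound 2 `COc1ccc(NC(=O)c2nnc(COc3ccc(CCC(=O)O)cc3)s2)cc1`, which in this assay gives > 10000 nM.

Within the data shown here, compound 2 stands at a limit rather than at a number: its result in this assay is the limit of > 10000 nM in this assay, at which 1 of the 2 values shown sits, so it is known only that the compound did not reach a measurable effect within the tested range. Among the measured compounds shown here, compound 1 is the only compound here with an actual number, and it differs from compound 2 in several places at once, so the two values show only that one compound is measurable and the other is not, and nothing can be drawn from them about any single change.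

Compound 3 `COc1cccc(NC(=O)c2nnc(COc3ccc(CCC(=O)O)cc3)s2)c1` has not yet been tested. Relative to compound 2 it carries the same atoms joined differently: 3-methoxyphenyl in place of 4-methoxyphenyl on an amide-type nitrogen. For the measured compounds named here, no step between two measured compounds that differ in one place is available to calibrate this change. Starting from a limit, the step from compound 2 to compound 3 is expected to be a step that the limit leaves unreadable from compound 2 to compound 3, no larger than the usual scatter. Compound 3 is therefore estimated at 12000 nM, within a range from 3000 nM to 40000 nM, with a real chance that this assay again returns only a limit.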

Compound 3, half-maximal effective concentration: 4680 nM
The estimate for compound 3 lay 2.6-fold (0.41 log units) above the measured number, and the stated range covers the measured number.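

Among these compounds, with 3-methoxyphenyl in place of 4-methoxyphenyl on the amide-type nitrogen, the change brings an at least 2.1-fold lower number from compound 2 to compound 3 (0.32 log units; beyond the scatter) in this assay and gives the first step that can be read at all. The two compounds hold the same atoms, so how the methoxy group is joined to this phenyl ring is enough on its own to separate a compound that gives a number from one that does not. This step is a lower bound and not a full size, because compound 2 is held only by a limit: the limit of > 10000 nM in this assay, at which 1 of the 3 values shown sits.

The compounds shown leave open whether a different group on the same amide-type nitrogen, such as 3-ethoxyphenyl or 3-chlorophenyl, would lower the number further than 3-methoxyphenyl does. Going by these compounds, compound 1 differs from compound 3 in several places, so it cannot show how much any single one of those differences counts, and the effect of a shorter chain carrying the carboxylic acid also remains open.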